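Replacing pyrrolidin-1-yl with cyclohexyl: working notes on the series

The source may report more compounds than this note shows. Statements on the series, on what has been measured and on what is new or still open speak of the compounds shown alone.

In a functional assay on U-87MG ATCC cells for inhibition, with U-87 MG (Homo sapiens) as the target, read by sulforhodamine B assay, with a stated time of 72 h (on this read-out higher numbers stand for an effect only at larger amounts of compound and lower numbers for an effect already at smaller amounts), compound 1 (`CSc1ccc(C(=O)/C=C/c2ccc([N+](=O)[O-])o2)cc1`) gives 3900 nM and compound 2 (`O=C(/C=C/c1ccc([N+](=O)[O-])o1)c1ccc(-n2ccnc2)cc1`) gives 13400 nM while compound 3 (`O=C(/C=C/c1ccc([N+](=O)[O-])o1)c1ccc(N2CCCC2)cc1`) gives 35400 nM as the highest number of the three.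

Among the compounds with values here, compound 4 (`O=C(/C=C/c1ccc([N+](=O)[O-])o1)c1ccc(C2CCCCC2)cc1`) carries cyclohexyl in place of pyrrolidin-1-yl on an aromatic carbon, para to a large group (cyclohexyl in place of pyrrolidin-1-yl on an aromatic carbon) and has no measurement yet.

Within the data shown here, no measured step involves cyclohexyl, so the only guide is the behaviour of other groups at this place. Pyrrolidin-1-yl came with the higher number both times, in a 9.1-fold higher number from compound 1 to compound 3 (0.96 log units; beyond the scatter) and in a 2.6-fold higher number from compound 2 to compound 3 (0.42 log units; beyond the scatter) as modest steps. The third step is a 3.4-fold higher number from compound 1 to compound 2 (0.54 log units; beyond the scatter) and is also modest.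

Since compound 3 stands at 35400 nM at the top of the three, leaving pyrrolidin-1-yl is expected to bring a modest fall in the number in this assay although three compounds are thin support. The estimated step is a 2.5-fold lower number from compound 3 to compound 4 (0.40 log units; beyond the scatter) as an expected move downward. For compound 4 the expected value is 14000 nM with an estimated range from 4500 nM to 38000 nM on this read-out.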

Compound 4, half-maximal effective concentration: 9500 nM
Compound 4: the middle estimate sits 1.5-fold (0.17 log units) above what was measured; the range from low to high includes it.
By their numbers in this assay, from the lowest: compound 1; then compounds 4 and 2 (each within the scatter of the next); then compound 3.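

In this assay, a ring of carbon only at this place gives a 3.7-fold lower number from compound 3 to compound 4 (0.57 log units; beyond the scatter), so the high number of compound 3 does not extend to every non-aromatic ring on this aromatic carbon. Cyclohexyl and 1H-imidazol-1-yl cannot be told apart here, with a 1.4-fold lower number from compound 2 to compound 4 (0.15 log units; within the scatter), although one ring is aromatic and the other is not, while methylsulfanyl keeps the lowest number of the four, with a 2.4-fold higher number from compound 1 to compound 4 (0.39 log units; beyond the scatter). Nothing available bears on the reason for these differences.

The compounds shown leave open how a primary amine or a carboxylic acid at this place would compare with methylsulfanyl. They also leave open whether a longer sulfur-linked chain, such as ethylsulfanyl, would stay close to compound 1 or move towards compound 4.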